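The source may report more compounds than this note shows. Statements on the series, on what has been measured and on what is new or still open speak of the compounds shown alone.

Measured so far in a functional assay on MDA-MB-231 cells (Homo sapiens) for cytotoxicity, read by MTT assay, with a stated time of 72 h; a lower number here means a stronger inhibitor, a higher number a weaker inhibitor:
- compound 1 `COc1ccc(Cn2nc(-c3ccccc3)c3cc(C(=N)Nc4cccc(C(F)(F)F)c4)nc(NC4CCCCC4)c32)cc1`: compound 1 gives > 50000 nM, which is a limit of this assay, not a number.
- compound 2 `N=C(Nc1cccc(C(F)(F)F)c1)c1cc2c(-c3ccccc3)n[nH]c2cn1`: compound 2 gives 22300 nM.

Compound 1 therefore stands only at a limit of this assay, with no measured number of its own (the limit of > 50000 nM in this assay, at which 1 of the 2 values shown sits). Among the measured compounds shown here, compound 2 shows a measured number, but no step between compound 1 and compound 2 is described, so only the two values themselves can be compared.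

Compound 3 `COc1ccc(Cn2nc(-c3ccccc3)c3cc(C(=N)Nc4cccc(C(F)(F)F)c4)nc(Nc4cc(OC)c(OC)c(OC)c4)c32)cc1` carries 3,4,5-trimethoxyphenyl in place of cyclohexyl on a nitrogen on an aromatic ring. For the measured compounds named here, no measured pair shows this change, so its size in this assay is unknown. The author expects compound 3 to remain weak, with a step from compound 1 to compound 3 of about an at least 1.4-fold lower number from compound 1 to compound 3 (0.15 log units; that floor lies within the scatter), possibly not beyond the scatter. The estimate for compound 3 is 35000 nM, within 8000 nM to 100000 nM.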

Compound 3, half-maximal inhibitory concentration: > 50000 nM
Compound 3: no number, only a limit (the forecaster's own chance of this, stated with the estimate: 45%); at least 1.4-fold (0.15 log units) between middle value and limit.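

Compound 1 and compound 3 both stand at a limit of this assay, not at a number, so no step between them can be read: the limit of > 50000 nM in this assay, at which 2 of the 3 values shown sit.

The compounds shown leave open whether 3,4,5-trimethoxyphenyl in place of cyclohexyl on a nitrogen on an aromatic ring changes the inhibitory concentration in this assay, and in which direction.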